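This account rests on a few compounds, and the source may have more. Where it says the series, first, only, none or still open, it means among the compounds named here.

Series notes in a functional assay on HepG2 cells (Homo sapiens) for antiproliferative activity, read by CCK-8 assay, with a stated time of 72 h; on this read-out lower numbers stand for stronger inhibition and higher numbers for weaker inhibition. Compound 1 `O=C(Nc1cccc(-c2oc3cc(-c4ccc(F)cc4)ccc3c(=O)c2O)c1)c1ccc(Cl)cc1` gives 11000 nM. Compound 2 `COc1ccccc1C(=O)Nc1cccc(-c2oc3cc(-c4ccc(F)cc4)ccc3c(=O)c2O)c1` gives 14500 nM. Compound 3 `O=C(Nc1cccc(-c2oc3cc(-c4ccc(F)cc4)ccc3c(=O)c2O)c1)c1ccc(C(F)(F)F)cc1` gives 42700 nM, the highest number of the three measured: a 3.9-fold higher number from compound 1 to compound 3 (0.59 log units; beyond the scatter) and a 2.9-fold higher number from compound 2 to compound 3 (0.47 log units; beyond the scatter) both lie beyond the scatter, whereas a 1.3-fold higher number from compound 1 to compound 2 (0.12 log units; within the scatter) stays within it.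

Compound 4 `CCc1ccc(C(=O)Nc2cccc(-c3oc4cc(-c5ccc(F)cc5)ccc4c(=O)c3O)c2)cc1` is the next step from compound 3: ethyl in place of trifluoromethyl on an aromatic carbon. Among the compounds with values here, no measured compound carries ethyl on this aromatic carbon, so the bearing of the earlier steps is indirect. The move from chloro to trifluoromethyl, a 3.9-fold higher number from compound 1 to compound 3 (0.59 log units; beyond the scatter), raised the number modestly; the move from 4-chlorophenyl to 2-methoxyphenyl, a 1.3-fold higher number from compound 1 to compound 2 (0.12 log units; within the scatter), did not move it beyond the scatter. Trifluoromethyl therefore stands out as the group with the highest number among the three amides. With ethyl entering in its place, compound 4 is expected to return toward the region of compound 1 and compound 2 rather than remain at the number of compound 3, and the estimated step is a 2.7-fold lower number from compound 3 to compound 4 (0.43 log units; beyond the scatter), a modest drop, though the width of the range reflects that no direct comparison exists. Compound 4 is estimated at 16000 nM, with a range from 6000 nM to 45000 nM.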

Compound 4, half-maximal inhibitory concentration: 20600 nM
For compound 4 the middle estimate is 1.3-fold (0.11 log units) below the measured one; the range from low to high includes it.
By their numbers in this assay, from the lowest: compounds 1, 2 and 4 (each within the scatter of the next); then compound 3.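

At this aromatic carbon, para to a large group, ethyl in place of trifluoromethyl gives a 2.1-fold lower number from compound 3 to compound 4 (0.32 log units; beyond the scatter) in this assay, so the high number of compound 3 is not shared by the other para-substituted amide with a carbon-linked group and goes with trifluoromethyl among the groups shown. The comparison with chloro at the same carbon, a 1.9-fold higher number from compound 1 to compound 4 (0.27 log units; within the scatter), and the one with the 2-methoxyphenyl amide, a 1.4-fold higher number from compound 2 to compound 4 (0.15 log units; within the scatter), both stay within the scatter, so compound 4 joins compound 1 and compound 2 as one group that these numbers cannot separate, with compound 3 alone standing apart from all three. Nothing at hand gives a reason for the separate place of trifluoromethyl at this carbon.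

On these data alone, whether methyl, a longer chain such as propyl, an amine or a carboxylic acid at this aromatic carbon would stay with that group, stand apart with compound 3, or reach clearly lower numbers remains open. As far as these compounds go, the four compounds also differ only at the acyl end of the amide, so the part played by the shared core in these numbers remains open too.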